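A Carboxylic Acid in Place of a Nitrile

The compounds below may be only part of what the source reports. "The series", "measured", "known", "first", "only" and "open" are said of these compounds alone.

Compound 2 `N#Cc1ccc(Nc2cc3[nH]c(-c4cccc(C(F)(F)F)c4)nc3cn2)nc1` carries a 5-cyanopyridin-2-yl group on a nitrogen attached to the shared core. In a physicochemical assay for solubility, using the shake flask method, in phosphate buffer, measured as kinetic solubility, with a stated time of 20 h, at pH 6.5 (on this read-out higher numbers stand for higher solubility and lower numbers for lower solubility), compound 2 gives < 5000 nM, which is a limit of the assay rather than a number. Compound 1 `COc1cccnc1Nc1cc2[nH]c(-c3cccc(C(F)(F)F)c3)nc2cn1` bears a 3-methoxypyridin-2-yl group in the same place. In this assay compound 1 gives < 5000 nM, likewise only a limit. The step that the two limits leave unreadable from compound 1 to compound 2 therefore cannot be read, and both results sit at the limit of < 5000 nM in this assay, at which 2 of the 2 values shown sit. Compound 3 `O=C(O)c1ccc(Nc2cc3[nH]c(-c4cccc(C(F)(F)F)c4)nc3cn2)nc1` differs from compound 2 by carboxy in place of cyano on an aromatic carbon. Going by the values given here, no measured step bears on this change: the single step in hand is unreadable, and two values resting at the same limit say nothing about direction or size. Any expectation for compound 3 in this assay can rest only on the change itself and on where compound 2 stands. The expected step of an at least 4.0-fold higher number from compound 2 to compound 3 (0.60 log units; beyond the scatter) is set upward, beyond the scatter, though with wide uncertainty. Compound 3 is therefore estimated at 20000 nM, within a range from 3000 nM to 150000 nM.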

Compound 3, solubility: 6000 nM
Compound 3: the middle estimate sits 3.3-fold (0.52 log units) above what was measured; low and high end bracket the measured number.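

In this assay compound 3 gives 6000 nM, the first result in this series that is a number and not a limit of the assay. At this place on the pyridine ring, two atoms from the ring nitrogen, carboxy in place of cyano gives an at least 1.2-fold higher number from compound 2 to compound 3 (0.07 log units; that floor lies within the scatter), and 5-carboxypyridin-2-yl in place of 3-methoxypyridin-2-yl gives an at least 1.2-fold higher number from compound 1 to compound 3 (0.07 log units; that floor lies within the scatter). Each step is only a floor, so neither is shown to reach beyond the scatter, and the true size stays unknown, with compound 1 and compound 2 both resting at a limit: the limit of < 5000 nM in this assay, at which 2 of the 3 values shown sit.

The compounds shown leave open how far the true step lies above its floor, since compound 2 has no number of its own in this assay. They also leave open whether other groups in the same place, such as a primary amide, a tetrazole, an amine or a carboxylic acid on a longer chain, would give a number in this assay and how that number would compare with compound 3.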